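Swapping the aryl group in a thromboxane synthase inhibitor

The source may report more compounds than this note shows. Statements on the series, on what has been measured and on what is new or still open speak of the compounds shown alone.

Of the compounds shown here, three have been measured in an assay (Equus caballus) for inhibition of Thromboxane-A synthase (Homo sapiens), using microsomes; on this read-out higher numbers stand for weaker inhibition and lower numbers for stronger inhibition. Compound 1 `NC(=O)CCCC/C=C(\c1ccccc1)c1cccnc1` gives 400 nM, compound 3 `O=C(O)CCCC/C=C\c1cccnc1` gives 250 nM, and compound 2 `Cc1ccsc1/C(=C/CCCCC(=O)O)c1cccnc1` gives 29 nM. Compound 2 therefore holds the lowest number of the three; its gap to compound 3 and its larger gap to compound 1 both lie beyond the scatter, so it counts as the strongest inhibitor among these. Among the measured compounds shown here, compound 1 and compound 3 differ from compound 2 in more than one place, so no single step between measured compounds is available.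

The next compound, compound 4 `O=C(O)CCCC/C=C(/c1ccc(Br)cc1)c1cccnc1`, keeps the acid chain and the pyridine-bearing double bond of compound 2 and changes only the aryl group: 4-bromophenyl in place of 3-methylthiophen-2-yl on a double-bonded chain carbon bound to an aromatic carbon and a double-bonded chain carbon. For the measured compounds named here, no measured pair shows what such a swap does on its own, so the expectation rests on the fact that compound 2 itself gives 29 nM and that the rest of the structure is unchanged. A step of modest size in the direction of weaker inhibition, or none beyond the scatter, is expected, with a 1.7-fold higher number from compound 2 to compound 4 (0.24 log units; within the scatter) as the estimated change. For compound 4 in this assay the estimated value is 50 nM, within a range from 15 nM to 170 nM.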

Compound 4, half-maximal inhibitory concentration: 82 nM
Estimate against measurement, compound 4: 1.6-fold (0.21 log units) below; the range from low to high includes it.
By their numbers in this assay, from the lowest: compound 2; then compound 4; then compounds 3 and 1 (each within the scatter of the next).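

Among the compounds shown here, with 4-bromophenyl in place of 3-methylthiophen-2-yl on a double-bonded chain carbon bound to an aromatic carbon and a double-bonded chain carbon, this assay shows a change beyond the scatter (a 2.8-fold higher number from compound 2 to compound 4 (0.45 log units; beyond the scatter)), the first single-place step in this set. It shows that inhibition at this position depends on which aryl group is present, and that of these two groups the 3-methylthiophen-2-yl gives the stronger inhibition, though the step is only modest. Nothing among the data explains the difference between the two aryl groups.

The compounds shown leave open whether an unsubstituted thiophen-2-yl or a 4-chlorophenyl here would stand nearer to compound 2 or to compound 4. They also leave open how a longer chain bearing the carboxylic acid would alter either result.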